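Furan-2-yl for thiophen-2-yl: inhibition expected unchanged

A few compounds are considered here, and "the series" means these few. Any claim that something is new, unique, unknown or untested is made for them only; others in the source may bear on it.

Compound 1 `Oc1cccc(-c2cc(-c3ccccc3)cc(-c3ccccc3)n2)c1` and compound 2 `Oc1cccc(-c2cc(-c3ccccc3)nc(-c3cccs3)c2)c1` share a core carrying a 3-hydroxyphenyl group and a phenyl group. In an assay on isolated protein for inhibition of DNA topoisomerase 1 (Homo sapiens), with a stated time of 30 min, tested at 20 uM (a higher number here means a stronger effect of the compound at the concentration tested, a lower number a weaker effect), compound 1 gives 0%, and compound 2 gives 2%. Compound 2 stands at the top of the two numbers shown, but compound 1, its nearest neighbour, lies within the scatter of it, so the two read as the same. For the measured compounds named here, no step between measured compounds covers the exchange in question. Compound 3 `Oc1cccc(-c2cc(-c3ccccc3)nc(-c3ccco3)c2)c1` differs from compound 2 by furan-2-yl in place of thiophen-2-yl on an aromatic carbon. Both measured compounds sit at the floor of the read-out in this assay, and nothing among them shows a move beyond the scatter, so the step from compound 2 to compound 3 is expected to be none beyond the scatter, no change at the digits printed from compound 2 to compound 3 (within the scatter). Compound 3 is accordingly estimated at 2% in this assay, with a range from 0% to 10%.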

Compound 3, a percentage reported as inhibition, at one concentration (the size of the read-out at that concentration, not a potency): 3.5%
For compound 3 the middle estimate is 1.5 percentage points below the measured one; measured number inside the range.
By their numbers in this assay, from the lowest: compounds 1, 2 and 3 (each within the scatter of the next).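

At the aromatic carbon next to the ring nitrogen, furan-2-yl in place of thiophen-2-yl gives, in this assay, a number 1.5 percentage points higher from compound 2 to compound 3 (within the scatter). For the compounds shown here, this is the first exchange that can be read at a single place, and it shows that oxygen for sulfur in this five-membered aromatic ring does not lift compound 3 off the floor of the read-out, so that the two rings cannot be told apart here. Nothing measured on these compounds bears on this result.

With both compounds at the floor, the step says little about how much this position can influence inhibition. From the compounds shown here alone, it remains open whether an amine, a carboxylic acid or a longer alkyl chain at this carbon, in place of the five-membered ring, would give a read-out beyond the scatter.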